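Swapping an amide for a fluorobenzyl ester

This account rests on a few compounds, and the source may have more. Where it says the series, first, only, none or still open, it means among the compounds named here.

Going by the values given here, compound 2 `CCn1c(C(=O)NCCCN(C)C)ccc1C(CC)(CC)c1ccc(OCC(O)C(C)(C)C)c(C)c1` is the only one of three measured compounds to give a number in an assay on HL-60 cells for agonist activity at vitamin D3 receptor (Homo sapiens), read by microscopy, with a stated time of 96 h; on this read-out lower numbers stand for an effect already at smaller amounts and higher numbers for an effect only at larger amounts of compound: compound 2 gives 37 nM. Compound 1 `CCOC(=O)CN(C)C(=O)c1ccc(C(CC)(CC)c2ccc(OCC(=O)C(C)(C)C)c(C)c2)n1CC` reaches only a limit of this assay, namely > 50000 nM. Compound 3 `CCn1c(C(=O)OCc2ccccn2)ccc1C(CC)(CC)c1ccc(OCC(=O)C(C)(C)C)c(C)c1` likewise sits at the limit > 50000 nM. Among the compounds with values here, the single measured step, a step that the two limits leave unreadable from compound 1 to compound 3, can therefore not be read for size, and the two limits point only to the limit of > 50000 nM in this assay, at which 2 of the 3 values shown sit. Compound 4 `CCn1c(C(=O)OCc2ccc(F)cc2)ccc1C(CC)(CC)c1ccc(OCC(O)C(C)(C)C)c(C)c1` differs from compound 2 by (4-fluorobenzyl)oxy in place of (3-(dimethylamino)propyl)amino on a carbonyl carbon. Within the data shown here, no measured step speaks to this change, so its direction and size stay open. Compound 4 is expected to give 300 nM, with a range of 20 nM to 20000 nM. This estimate means an expected step of an 8.1-fold higher number from compound 2 to compound 4 (0.91 log units; beyond the scatter), wider than the usual scatter yet uncertain in direction.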

Compound 4, half-maximal effective concentration: > 50000 nM
Compound 4 gave a limit, no number (the forecaster's own chance of this, stated with the estimate: 25%); middle value at least 160-fold (2.22 log units) away from the limit.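

On this carbonyl carbon, with the rest of compound 2 unchanged, (4-fluorobenzyl)oxy in place of (3-(dimethylamino)propyl)amino gives an at least 1300-fold higher number from compound 2 to compound 4 (3.13 log units; beyond the scatter). Going by these compounds alone, this is the first step here that can be read, and it shows that this one group alone separates a measured number from a limit in this assay. Compound 4 gives only a limit, which leaves compound 2 as the sole number: the limit of > 50000 nM in this assay, at which 3 of the 4 values shown sit.

What the compounds shown leave open is whether the link to the carbonyl or the rest of the group counts. A (4-fluorobenzyl)amino or (3-(dimethylamino)propyl)oxy group on the same carbonyl carbon would separate the two.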